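Stripping the phenyl ring bare

A few compounds are considered here, and "the series" means these few. Any claim that something is new, unique, unknown or untested is made for them only; others in the source may bear on it.

In a functional assay on SK-OV-3 cells (Homo sapiens) for cytotoxicity (a higher number here means a weaker inhibitor, a lower number a stronger inhibitor), compound 1 `C=C/C=C\[C@H](C)[C@H](OC(N)=O)[C@@H](C)[C@H](O)[C@@H](C)C/C(C)=C\[C@H](C)[C@@H](O)[C@@H](C)/C=C\CCc1ccc(Oc2ccccc2)cc1` gives 10000 nM, compound 2 `C=C/C=C\[C@H](C)[C@H](OC(N)=O)[C@@H](C)[C@H](O)[C@@H](C)C/C(C)=C\[C@H](C)[C@@H](O)[C@@H](C)/C=C\CCc1ccc(C)c(F)c1` gives 1000 nM and compound 3 `C=C/C=C\[C@H](C)[C@H](OC(N)=O)[C@@H](C)[C@H](O)[C@@H](C)C/C(C)=C\[C@H](C)[C@@H](O)[C@@H](C)/C=C\CCc1ccc(C)c(O)c1` gives 410 nM, the lowest of the three numbers. Compound 4 `C=C/C=C\[C@H](C)[C@H](OC(N)=O)[C@@H](C)[C@H](O)[C@@H](C)C/C(C)=C\[C@H](C)[C@@H](O)[C@@H](C)/C=C\CCc1ccccc1` has phenyl in place of 3-hydroxy-4-methylphenyl on a saturated chain carbon, two bonds along the chain from a double-bonded chain carbon. Among the compounds with values here, one measured step bears on this: hydroxy in place of fluoro on an aromatic carbon gave a 2.4-fold lower number from compound 2 to compound 3 (0.39 log units; beyond the scatter), a modest change. Within the data shown here, no measured pair tests the methyl group alone. Removing the hydroxy should therefore raise the number by a similarly modest amount, so the expected step is a 2.4-fold higher number from compound 3 to compound 4 (0.39 log units; beyond the scatter). For compound 4 the estimated value is 1000 nM, with an expected range of 300 nM to 4000 nM.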

Compound 4, half-maximal inhibitory concentration: 350 nM
Compound 4: the middle estimate sits 2.9-fold (0.46 log units) above what was measured; the measured number falls inside the stated range.
By their numbers in this assay, from the lowest: compounds 4 and 3 (each within the scatter of the next); then compound 2; then compound 1.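

In this assay the bare phenyl ring gives a 1.2-fold lower number from compound 3 to compound 4 (0.07 log units; within the scatter), so neither the hydroxy nor the methyl of the 3-hydroxy-4-methylphenyl group is needed to hold this level. The fluoro-bearing ring of compound 2 falls short of the bare ring, with a 2.9-fold lower number from compound 2 to compound 4 (0.46 log units; beyond the scatter) as the step. The biggest change comes with hydrogen in place of phenoxy, a 29-fold lower number from compound 1 to compound 4 (1.46 log units; beyond the scatter), which marks the large phenoxy-bearing ring as the poorest of these four.

On these data alone, whether an amine or a carboxylic acid on this ring, or a longer chain leading to it, would lower the number remains open. Why these rings differ also stays unexplained, as no supporting evidence on the cause is available.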